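The compounds below may be only part of what the source reports. "The series", "measured", "known", "first", "only" and "open" are said of these compounds alone.

Working notes on the hydroxamic acid series and an assay on Sf9 cells for inhibition of protein deacetylase HDAC6 (Homo sapiens), read by fluorescence, with a stated time of 40 min, tested at 100 nM; a lower number here means less inhibition, a higher number more inhibition at the concentration tested (going by the name of the read-out).

Of the compounds shown here, three have been measured. Compound 1 `O=C(NO)c1ccc(NCc2nc(-c3cccc(Cl)c3)nn2-c2ccccc2)cc1` gives 61.2%. Compound 2 `O=C(NO)c1ccc(NCc2nc(-c3ccccc3)nn2-c2ccc(Br)cc2)cc1` gives 65.9%. Compound 3 `O=C(NO)c1ccc(NCc2nc(-c3ccc(Cl)c(Cl)c3)nn2-c2ccccc2)cc1` gives 34.5%. Compound 2 and compound 1 lie within the scatter of each other, so no order between them can be claimed; compound 3 lies beyond the scatter below both.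

Within the data shown here, the one step between compounds differing in a single place is a number 26.7 percentage points lower from compound 1 to compound 3 (beyond the scatter), and it concerns a chloro added on the phenyl attached to a ring carbon of the shared core. Compound 1 and compound 2 differ in two places, so their two values stand alone.

Compound 4 `Cc1ccc(-n2nc(-c3ccccc3)nc2CNc2ccc(C(=O)NO)cc2)cc1C` is still to be measured. Its change from compound 2 is 3,4-dimethylphenyl in place of 4-bromophenyl on an aromatic nitrogen. Among the measured compounds shown here, no measured step concerns the group on the aromatic nitrogen, so the step from compound 1 to compound 3 bears on it only indirectly as a sign that aryl substitution can shift the read-out. The expectation is a step of a number 7.9 percentage points lower from compound 2 to compound 4 (within the scatter), with a change not clearly beyond the scatter in either direction. Compound 4 is therefore estimated at 58%, within 35% to 78%.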

Compound 4, a percentage reported as inhibition, at one concentration (the size of the read-out at that concentration, not a potency): 53%
The estimate for compound 4 lay 5 percentage points above the measured number, and the stated range covers the measured number.
By their numbers in this assay, from the lowest: compound 3; then compounds 4, 1 and 2 (each within the scatter of the next, the first and the last beyond it).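

In this assay the group on the aromatic nitrogen now has a step of its own: 3,4-dimethylphenyl in place of 4-bromophenyl gives a number 12.9 percentage points lower from compound 2 to compound 4 (beyond the scatter), so the read-out responds to a change at this position. Among these compounds, until now the only readable step lay on the phenyl attached to a ring carbon of the shared core, and this one shows that the aryl group on the aromatic nitrogen also counts, though a single pair gives no trend. No measurement at hand gives a reason for this step.

The compounds shown do not separate the loss of the bromo group from the entry of the two methyl groups. From the compounds shown here alone, how an amine or a carboxylic acid on this phenyl ring would read in this assay also remains open.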